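The compounds below may be only part of what the source reports. "The series", "measured", "known", "first", "only" and "open" are said of these compounds alone.

Compound 1 `CC(C)=CC[C@@H](OC[C@@H](C)O)C1=CC(=O)c2c(O)ccc(O)c2C1=O` gives 14300 nM in a functional assay on DU-145 cells (Homo sapiens) for cytotoxicity, read by MTT assay; a lower number here means a stronger inhibitor, a higher number a weaker inhibitor. Compound 2 `CC[C@@](C)(O)CC(=O)O[C@H](CC=C(C)C)C1=CC(=O)c2c(O)ccc(O)c2C1=O` gives 12700 nM. Compound 3 `CCC(O)(CC)CC(=O)O[C@H](CC=C(C)C)C1=CC(=O)c2c(O)ccc(O)c2C1=O` gives 67000 nM.

Compound 1 has the second highest of these three numbers. It sits closest to compound 2, with a 1.1-fold lower number from compound 1 to compound 2 (0.05 log units; within the scatter), and furthest from compound 3, with a 4.7-fold higher number from compound 1 to compound 3 (0.67 log units; beyond the scatter). Between the two esters, a 5.3-fold higher number from compound 2 to compound 3 (0.72 log units; beyond the scatter) shows that the bulkier carbinol end costs potency.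

Compound 4 `CC(=O)OC(C)CO[C@H](CC=C(C)C)C1=CC(=O)c2c(O)ccc(O)c2C1=O` differs from compound 1 in this way: 1-acetoxyethyl in place of 1-hydroxyethyl on a saturated chain carbon bound to an oxygen on a saturated carbon. Among the measured compounds shown here, none of the measured steps makes this same change; the two known steps from compound 1 replace the whole 2-hydroxypropyl chain with esters that keep a hydroxyl, whereas here the hydroxyl itself is capped while the chain stays. The nearest hint is that a small addition on this side chain left the number unchanged within the scatter from compound 1 to compound 2, while a larger one weakened compound 3. Compound 4 is therefore expected to stay near compound 1, with a value estimated at 20000 nM, between 7000 nM and 60000 nM. The expected step is a 1.4-fold higher number from compound 1 to compound 4 (0.15 log units; within the scatter), a shift not clearly beyond the scatter.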

Compound 4, half-maximal inhibitory concentration: 16600 nM
For compound 4 the middle estimate is 1.2-fold (0.08 log units) above the measured one; measured number inside the range.
By their numbers in this assay, from the lowest: compounds 2, 1 and 4 (each within the scatter of the next); then compound 3.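

In this assay, capping the hydroxyl as 2-acetoxypropyl in place of 2-hydroxypropyl gives a 1.2-fold higher number from compound 1 to compound 4 (0.06 log units; within the scatter), so a free hydroxyl on this chain is not needed to hold the number seen for compound 1. The earlier esters both kept a hydroxyl, so they could not show this. The capped chain also compares with those esters, with a 1.3-fold higher number from compound 2 to compound 4 (0.12 log units; within the scatter) and a 4.0-fold lower number from compound 3 to compound 4 (0.61 log units; beyond the scatter), which leaves compound 3 as the only one of the four set apart from the others. No measurement here explains these results.

From the compounds shown here alone, compound 4 has no defined stereocentre at the capped carbon, so the role of that centre stays open. Also open, going by these compounds, is whether an amine or a carboxylic acid at the end of this chain would hold the number.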